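The source may report more compounds than this note shows. Statements on the series, on what has been measured and on what is new or still open speak of the compounds shown alone.

Of the compounds shown here, three built on one shared core have been tested in an assay on CHO cells for displacement of a labelled ligand from prostaglandin E2 receptor EP3 subtype (Homo sapiens), read by radioligand binding; on this read-out higher numbers stand for weaker inhibition and lower numbers for stronger inhibition. Compound 1 `CC(C)C(Cc1ncc[nH]1)c1ccc(-c2ccc3cccc(F)c3c2)[nH]c1=O` gives 11 nM, compound 2 `CC(C)C(c1ncco1)c1ccc(-c2ccc3cccc(F)c3c2)[nH]c1=O` gives 24 nM, and compound 3 `CC(C)C(c1noc(=O)[nH]1)c1ccc(-c2ccc3cccc(F)c3c2)[nH]c1=O` gives 15 nM. Compound 3 stands second highest of these three numbers, yet both of its neighbours lie within the scatter: a 1.4-fold higher number from compound 1 to compound 3 (0.13 log units; within the scatter) and a 1.6-fold lower number from compound 2 to compound 3 (0.20 log units; within the scatter). Compound 4 `Cc1c[nH]c(C(c2ccc(-c3ccc4cccc(F)c4c3)[nH]c2=O)C(C)C)n1` differs from compound 3 by a group of 6 heavy atoms (4 carbon, 2 nitrogen; one five-membered aromatic ring with 2 hetero atoms) in place of a group of 6 heavy atoms (2 carbon, 2 nitrogen, 2 oxygen; one five-membered aromatic ring with 3 hetero atoms), on a saturated chain carbon bound to an aromatic carbon and a saturated chain carbon. The step from compound 1 to compound 3 is the nearest guide, exchanging a five-membered ring with 2 hetero atoms for one with 3, and it hardly moved the number; the step from compound 2 to compound 3 also stayed within the scatter. Returning to a ring with 2 hetero atoms is therefore expected to change little in this assay, perhaps giving a slightly lower number. For compound 4 the estimated value is 12 nM, between 5 nM and 30 nM. That estimate means a 1.3-fold lower number from compound 3 to compound 4 (0.10 log units; within the scatter).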

Compound 4, inhibition constant: 12 nM
Estimate against measurement, compound 4: no gap at the digits printed; measured number inside the range.
By their numbers in this assay, from the lowest: compounds 1, 4, 3 and 2 (each within the scatter of the next, the first and the last beyond it).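

In this assay the 4-methyl-1H-imidazol-2-yl group of compound 4 stays within the scatter of all three earlier groups, with a 1.3-fold lower number from compound 3 to compound 4 (0.10 log units; within the scatter) and a 2.0-fold lower number from compound 2 to compound 4 (0.30 log units; within the scatter) and also a 1.1-fold higher number from compound 1 to compound 4 (0.04 log units; within the scatter). An imidazole ring bound directly to the saturated chain carbon therefore reads the same, within the scatter, as the (1H-imidazol-2-yl)methyl group. Nothing measured here explains these numbers. The ring methyl cannot be judged alone, since the step from compound 1 also removes the chain link. Going by these compounds, how an amine or a carboxylic acid would read at this place stays open.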